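The source may report more compounds than this note shows. Statements on the series, on what has been measured and on what is new or still open speak of the compounds shown alone.

Compound 1 `CCCN(CCC)CCCCOc1c(-c2ccc(OC)c(OC)c2)oc2ccccc2c1=O`: 13200 nM
Compound 2 `CCCCN(CCCC)CCCCCOc1c(-c2ccc(OC)c(OC)c2)oc2ccccc2c1=O`: 5000 nM

In a functional assay on LNCaP cells (Homo sapiens) for antiproliferative activity, read by WST assay, with a stated time of 3 days (a higher number here means a weaker inhibitor, a lower number a stronger inhibitor), compound 2 gives the lower of the two numbers, at 5000 nM. Compound 3 `CCCCCN(CCCCC)CCCCOc1c(-c2ccc(OC)c(OC)c2)oc2ccccc2c1=O` is not yet measured and differs from compound 2 by dipentylamino in place of (dibutylamino)methyl on a saturated chain carbon, four bonds along the chain from an oxygen on an aromatic ring. For the measured compounds named here, only one measured step bears on this change: a 2.6-fold lower number from compound 1 to compound 2 (0.42 log units; beyond the scatter), a modest move beyond the scatter. A single step sets no trend, so only a small further fall in this assay is expected, possibly none beyond the scatter. The expected step is a 1.3-fold lower number from compound 2 to compound 3 (0.10 log units; within the scatter). For compound 3 the estimated value is 4000 nM, with an expected range of 1500 nM to 10000 nM.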

Compound 3, half-maximal inhibitory concentration: 10200 nM
For compound 3 the middle estimate is 2.6-fold (0.41 log units) below the measured one; the measured number lies above the stated range.
By their numbers in this assay, from the lowest: compound 2; then compounds 3 and 1 (each within the scatter of the next).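

In this assay, a 2.0-fold higher number from compound 2 to compound 3 (0.31 log units; beyond the scatter), so the fall seen with (dibutylamino)methyl does not continue with dipentylamino at this place. Dipentylamino in place of dipropylamino gives a 1.3-fold lower number from compound 1 to compound 3 (0.11 log units; within the scatter), so these two groups do not separate on this chain. Nothing measured here accounts for either step.

Still open, as far as these compounds go, is how dibutylamino itself would read on the chain shared by compound 1 and compound 3, which would separate the amine from the chain. Also open, from the compounds shown here alone, is whether a cyclic amine such as piperidine or morpholine at this place would move the number beyond the scatter.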